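The compounds below may be only part of what the source reports. "The series", "measured", "known", "first", "only" and "open" are said of these compounds alone.

Measured so far in an assay on HL-60 cells for agonist activity at vitamin D3 receptor (Homo sapiens), read by microscopy, with a stated time of 96 h; a lower number here means that less compound is needed, a higher number that more compound is needed for the effect:
compound 1 `CC[C@@H](C)[C@H](NC(=O)c1ccc(C(CC)(CC)c2ccc(OCC(=O)C(C)(C)C)c(C)c2)n1CC)C(=O)OC` gives 590 nM
compound 2 `C#CC(C)OC(=O)c1ccc(C(CC)(CC)c2ccc(OCC(=O)C(C)(C)C)c(C)c2)n1CC` gives 210 nM
compound 3 `CC[C@@H](C)[C@H](NC(=O)c1ccc(C(CC)(CC)c2ccc(OCC(O)C(C)(C)C)c(C)c2)n1CC)C(=O)OC` gives 26 nM

Compound 3 stands lowest of the three, and its steps to compound 2 and to compound 1 are both beyond the scatter. Compound 4 `CCN(CC)CCNC(=O)c1ccc(C(CC)(CC)c2ccc(OCC(O)C(C)(C)C)c(C)c2)n1CC` differs from compound 3 by 2-(diethylamino)ethyl in place of 1-(methoxycarbonyl)-2-methylbutyl on an amide-type nitrogen. Among the compounds with values here, the only measured step touching that position is a 2.8-fold lower number from compound 1 to compound 2 (0.45 log units; beyond the scatter), a modest one, while the large change a 23-fold lower number from compound 1 to compound 3 (1.36 log units; beyond the scatter) concerns a different part of the molecule that compound 4 keeps unchanged. Within the data shown here, with only one modest precedent, a small step is expected here, in either direction, a 1.3-fold higher number from compound 3 to compound 4 (0.13 log units; within the scatter). Compound 4 is therefore estimated at 35 nM, with a range from 10 nM to 130 nM.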

Compound 4, half-maximal effective concentration: 110 nM
The estimate for compound 4 lay 3.1-fold (0.50 log units) below the measured number; measured number inside the range.
By their numbers in this assay, from the lowest: compound 3; then compounds 4 and 2 (each within the scatter of the next); then compound 1.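

Within the data shown here, with the hydroxy group held constant, the side chain on the amide-type nitrogen is changed on its own for the first time, and 2-(diethylamino)ethyl in place of 1-(methoxycarbonyl)-2-methylbutyl gives a 4.2-fold higher number from compound 3 to compound 4 (0.63 log units; beyond the scatter) in this assay. The step is modest, and compound 4 reaches 110 nM with no defined stereocentre in this chain. No measurement shown here explains the step. The compounds shown leave open whether the methyl ester or the diethylamino group accounts for it. A carboxylic acid in place of that ester, or a plain pentyl chain on the nitrogen, would separate the two.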